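The source may report more compounds than this note shows. Statements on the series, on what has been measured and on what is new or still open speak of the compounds shown alone.

Measured so far:
compound 1 `C=CC1=C(C(=O)NCCC)C(c2ccc(F)cc2)OC1` — in a functional assay on A549 cells (Homo sapiens) for cytotoxicity, read by MTT assay, with a stated time of 24 h (a lower number here means a stronger inhibitor, a higher number a weaker inhibitor), compound 1 gives > 100000 nM, a limit of the assay.
compound 2 `C=CC1=C(C(=O)O)C(c2ccc(F)cc2)OC1` — in this assay compound 2 gives > 100000 nM, a limit of the assay.
compound 3 `C=CC1=C(C(=O)NCC(C)C)C(c2ccc(F)cc2)OC1` — in this assay compound 3 gives > 100000 nM, a limit of the assay.

Compound 3 thus stands at the limit of > 100000 nM in this assay, at which 3 of the 3 values shown sit, with nothing to separate it from the other two. The next compound, compound 4 `C=CC1=C(C(=O)NC2CCCCC2)C(c2ccc(F)cc2)OC1`, carries cyclohexyl in place of isobutyl on an amide-type nitrogen. The steps a step that the two limits leave unreadable from compound 2 to compound 3 and a step that the two limits leave unreadable from compound 1 to compound 3 bear on the amide substituent, and a step that the two limits leave unreadable from compound 1 to compound 2 sits alongside; none of them gives a readable size, so no direction can be read for the step in this assay. Compound 4 is expected to remain at the limit as well, estimated at 150000 nM with a range of 30000 nM to 600000 nM. The expected step that the limit leaves unreadable from compound 3 to compound 4 is itself only an estimate, not beyond the scatter.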

Compound 4, half-maximal inhibitory concentration: > 100000 nM
Compound 4 ended at the assay's limit (the forecaster's own chance of this, stated with the estimate: 85%); the middle value lies beyond the limit too.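

In this assay, for the compounds shown here, compound 4 sits at a limit, as do compound 1, compound 2 and compound 3, so no step among them can be read. The compounds shown leave open whether any amide substituent on this core gives a readable value.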